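This account rests on a few compounds, and the source may have more. Where it says the series, first, only, none or still open, it means among the compounds named here.

Measured compounds:
compound 1 `CC[C@@H](C)[C@H](NC(=O)c1ccc(C(CC)(CC)c2ccc(OCC(=O)C(C)(C)C)c(C)c2)n1CC)C(=O)OC`: 590 nM
compound 2 `CCn1c(C(=O)OC(C)CCO)ccc1C(CC)(CC)c1ccc(OCC(=O)C(C)(C)C)c(C)c1`: 380 nM

In an assay on HL-60 cells for agonist activity at vitamin D3 receptor (Homo sapiens), read by microscopy, with a stated time of 96 h (a lower number here means that less compound is needed, a higher number that more compound is needed for the effect), compound 1 gives 590 nM, and the step of a 1.6-fold lower number from compound 1 to compound 2 (0.19 log units; within the scatter) shows that compound 1 and compound 2 cannot be told apart on these two numbers. Compound 3 `CCOC(=O)c1ccc(OC(=O)c2ccc(C(CC)(CC)c3ccc(OCC(=O)C(C)(C)C)c(C)c3)n2CC)cc1` differs from compound 1 by 4-(ethoxycarbonyl)phenoxy in place of (1-(methoxycarbonyl)-2-methylbutyl)amino on a carbonyl carbon. Within the data shown here, the one measured step also replaced the group on that carbonyl carbon and stayed within the scatter, so no step beyond the scatter is expected in this assay here either. Compound 3 is therefore estimated at 500 nM, with a range from 200 nM to 1300 nM, which means an expected step of a 1.2-fold lower number from compound 1 to compound 3 (0.07 log units; within the scatter).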

Compound 3, half-maximal effective concentration: 45600 nM
The estimate for compound 3 lay 91-fold (1.96 log units) below the measured number, and the stated range ends below it.
By their numbers in this assay, from the lowest: compounds 2 and 1 (each within the scatter of the next); then compound 3.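

At this carbonyl carbon the attached group does matter: in this assay there is a 77-fold higher number from compound 1 to compound 3 (1.89 log units; beyond the scatter) when 4-(ethoxycarbonyl)phenoxy enters, and a 120-fold higher number from compound 2 to compound 3 (2.08 log units; beyond the scatter) against the other ester. Of the three groups compared, only this one carries an aromatic ring, so a large step is tied to this change, though a link between the ring and the step is not established. No measurement here gives a cause for the step. From the compounds shown here alone, it remains open whether the ring itself or its ethoxycarbonyl group goes with the higher number. An unsubstituted phenoxy group or a carboxylic acid on the ring would help separate these two.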